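Removing the chloro from compound 2

The compounds below may be only part of what the source reports. "The series", "measured", "known", "first", "only" and "open" are said of these compounds alone.

Of the compounds shown here, two built on one shared core have been measured in a functional assay, with a stated time of 90 s; on this read-out higher numbers stand for weaker inhibition and lower numbers for stronger inhibition. Compound 1 `Cc1nc2c3ccccc3ccc2c2nc3c(ccc4ccccc43)c(-c3cc([N+](=O)[O-])ccc3N)c12` gives 110 ug/mL. Compound 2 `Cc1nc2c3ccccc3ccc2c2nc3c(ccc4ccccc43)c(-c3ccccc3Cl)c12` gives 170 ug/mL in this assay. Among the measured compounds shown here, the single step between them, a 1.5-fold higher number from compound 1 to compound 2 (0.19 log units; within the scatter), is within the scatter, so compound 2 stands within the scatter of the only other number, that of compound 1, and the two cannot be told apart.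

Compound 3 `Cc1nc2c3ccccc3ccc2c2nc3c(ccc4ccccc43)c(-c3ccccc3)c12` has not yet been measured in this assay. It differs from compound 2 by hydrogen in place of chloro on an aromatic carbon; what leaves is a single chlorine, no ring, and only a hydrogen atom enters, so read one bond further out the change is 2-chlorophenyl to phenyl. For the measured compounds named here, the only measured step touching this ring is a 1.5-fold higher number from compound 1 to compound 2 (0.19 log units; within the scatter), where a far larger exchange of the whole substituted ring left the number within the scatter. A smaller change at the same ring is therefore expected to produce no step beyond the scatter in either direction. The estimate for compound 3 in this assay is 170 ug/mL, with a range from 80 ug/mL to 360 ug/mL. The step expected from this is no change at the digits printed from compound 2 to compound 3 (within the scatter).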

Compound 3, half-maximal inhibitory concentration: 188 ug/mL
Compound 3: the middle estimate sits 1.1-fold (0.04 log units) below what was measured; measured number inside the range.
By their numbers in this assay, from the lowest: compounds 1, 2 and 3 (each within the scatter of the next).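

In this assay, taking the chloro off the ring gives a 1.1-fold higher number from compound 2 to compound 3 (0.04 log units; within the scatter), so at this ortho place the chlorine and a hydrogen cannot be told apart. Compound 3 also supplies the bare phenyl as a reference for this ring, and going to it from the 2-amino-5-nitrophenyl group gives a 1.7-fold higher number from compound 1 to compound 3 (0.23 log units; within the scatter), so neither the single chloro nor the amino and nitro groups together show a step beyond the scatter against the unsubstituted ring. All three compounds therefore stand within the scatter of one another, and no independent data bear on what lies behind this flat result.

On these data alone, all three compounds keep a six-membered aromatic ring of carbon only on this aromatic carbon, so it remains open whether any change here can move the number beyond the scatter. A carboxylic acid or a dimethylamine on the phenyl, or a cyclohexyl ring or a longer alkyl chain in place of the phenyl, would put that question to a much larger change than any of the steps shown.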